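From cyano to nitro in an antiproliferative series

The compounds below may be only part of what the source reports. "The series", "measured", "known", "first", "only" and "open" are said of these compounds alone.

Compound 1 `CC(O)(CSc1cccc(S(F)(F)(F)(F)F)c1)C(=O)Nc1ccc(C#N)cc1C(F)(F)F`: 17600 nM
Compound 2 `CC(O)(CSc1ccc(S(F)(F)(F)(F)F)cc1)C(=O)Nc1ccc(S(F)(F)(F)(F)F)cc1`: 18300 nM
Compound 3 `CC(O)(COc1ccc(S(F)(F)(F)(F)F)cc1)C(=O)Nc1ccc(C#N)c(C(F)(F)F)c1`: 11500 nM

All three compounds were measured in a functional assay on LNCaP cells (Homo sapiens) for antiproliferative activity, read by propidium iodide staining, with a stated time of 96 h (on this read-out lower numbers stand for stronger inhibition and higher numbers for weaker inhibition), and gave numbers in the same narrow band. Compound 3 (11500 nM) lies within the scatter of both compound 1 (17600 nM) and compound 2 (18300 nM), so these values do not separate the three structures.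

The next compound is compound 4 `CC(O)(COc1ccc(S(F)(F)(F)(F)F)cc1)C(=O)Nc1ccc([N+](=O)[O-])c(C(F)(F)F)c1`, which carries nitro in place of cyano on an aromatic carbon, ortho to a trifluoromethyl group (nitro in place of cyano on an aromatic carbon). For the measured compounds named here, no two measured compounds differ in only one place, so the data hold no direct measure of this exchange. The expectation therefore rests on the close values alone, with compound 3 (11500 nM) as the starting point. In this assay no change beyond the scatter is expected, and the estimate is a 1.0-fold lower number from compound 3 to compound 4 (0.02 log units; within the scatter) (a small step at most). Compound 4 is expected to read 11000 nM (estimated range 5000 nM to 25000 nM).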

Compound 4, half-maximal inhibitory concentration: 100000 nM
Estimate against measurement, compound 4: 9.1-fold (0.96 log units) below, and the stated range ends below it.
By their numbers in this assay, from the lowest: compounds 3, 1 and 2 (each within the scatter of the next); then compound 4.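

In this assay, for the compounds shown here, the exchange of cyano for nitro gives the first single change that can be read, with an 8.7-fold higher number from compound 3 to compound 4 (0.94 log units; beyond the scatter) marking a real weakening rather than a shift within the scatter. The earlier compounds shown here, whose close values came from structures differing in more than one place, could not show that this aromatic carbon, ortho to a trifluoromethyl group and para to a large group, responds to the group placed on it. The data shown offer no measurement that accounts for this weakening.

Going by these compounds, whether it is particular to nitro, or would also follow an amine, a carboxylic acid or a chlorine atom on this carbon, remains open. Also open, on these data alone, is whether the exchange would have the same size with sulfur in place of the chain oxygen of compound 3.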